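Swapping the Benzamide Ring: From Compound 2 to Compound 4

The compounds below may be only part of what the source reports. "The series", "measured", "known", "first", "only" and "open" are said of these compounds alone.

Within the data shown here, compound 2 `O=C(Nc1ccc(Cl)c(-c2nnc3c(Cl)cccn23)c1)c1cccc(Cl)c1` is the one member of this small set that yields an actual number in a functional assay on MDA-MB-468 cells (Homo sapiens) for antiproliferative activity, read by MTT assay, with a stated time of 72 h (a lower number here means a stronger inhibitor, a higher number a weaker inhibitor), where compound 2 gives 54800 nM. Compound 1 `O=C(Nc1ccc(Cl)c(-c2nnc3c(Cl)cccn23)c1)c1ccc(Cl)cc1` is reported in this assay only as a limit, > 100000 nM. Compound 3 `CS(=O)(=O)c1ccc(C(=O)Nc2ccc(Cl)c(-c3nnc4c(Cl)cccn34)c2)c(Cl)c1` likewise reaches only a limit in this assay, > 100000 nM. Two of the three results thus sit at the limit of > 100000 nM in this assay, at which 2 of the 3 values shown sit, so compound 2 stands alone with a measured value, and a weak one.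

Among the measured compounds shown here, the step of an at least 1.8-fold lower number from compound 1 to compound 2 (0.26 log units; that floor lies within the scatter) is the only measured comparison: shifting a single chlorine around the ring on the carbonyl carbon moved the number by no more than the scatter allows. Compound 4 `O=C(Nc1ccc(Cl)c(-c2nnc3c(Cl)cccn23)c1)c1c(F)cccc1Cl` differs from compound 2 by 2-chloro-6-fluorophenyl in place of 3-chlorophenyl on a carbonyl carbon. For the measured compounds named here, no measured step covers a ring carrying two halogens, so that single step is the only guide, and it points to a small effect at most.

Compound 4 is therefore expected to remain close to compound 2, with a 1.1-fold higher number from compound 2 to compound 4 (0.04 log units; within the scatter) as the anticipated step, in either direction but not beyond the scatter. Compound 4 is estimated at 60000 nM, within 20000 nM to 150000 nM, with a real chance that only a limit is returned.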

Compound 4, half-maximal inhibitory concentration: 57600 nM
Compound 4: the middle estimate sits 1.0-fold (0.02 log units) above what was measured; the measured number falls inside the stated range.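

Moving from 3-chlorophenyl to 2-chloro-6-fluorophenyl on the carbonyl carbon gives a 1.1-fold higher number from compound 2 to compound 4 (0.02 log units; within the scatter) in this assay, so a ring with two halogens reads the same as a ring with one. The earlier compounds shown here showed only a single chlorine changing place on this ring, and compound 4 extends that flat picture to a ring with a fluorine as well, though the number stays weak. The other new comparison, an at least 1.7-fold lower number from compound 1 to compound 4 (0.23 log units; that floor lies within the scatter), rests on a limit and gives only a floor, and much of this small set stays at that ceiling: the limit of > 100000 nM in this assay, at which 2 of the 4 values shown sit.

No ring shown at this position brings the number anywhere near a strong result, so it remains open whether an amine or a carboxylic acid on the ring, or a longer chain in place of the ring, would shift it beyond the scatter. As far as these compounds go, it also remains open whether changes to the shared core, rather than to the benzamide ring, would matter more in this assay.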